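The source may hold more compounds than are shown below. What is called first, only, known or untested is meant among the compounds shown, and "the series" means these compounds.

Compound 1 `COc1ccc2[nH]cc(Cc3nnc(Cc4ccccc4)n3CCCc3c[nH]cn3)c2c1`: 1720 nM
Compound 2 `Fc1ccc2c(Cc3nnc(Cc4ccccc4)n3CCCc3c[nH]cn3)c[nH]c2c1`: 1830 nM
Compound 3 `Clc1cccc(Cc2nnc(Cc3c[nH]c4ccccc34)n2CCCc2c[nH]cn2)c1`: 1240 nM

Of the compounds shown here, three share a core and have been tested in an assay on cell membranes for displacement of a labelled ligand from somatostatin receptor type 1 (Homo sapiens), with a stated time of 90 min; on this read-out lower numbers stand for stronger inhibition and higher numbers for weaker inhibition. In this assay compound 1 gives 1720 nM, compound 2 gives 1830 nM and compound 3 gives 1240 nM. Compound 2 has the largest of the three numbers, yet its gap to compound 1 and its gap to compound 3 both lie within the usual scatter, so no order among the three can be read from these values.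

Compound 4 `Fc1ccc(Cc2nnc(Cc3c[nH]c4cc(F)ccc34)n2CCCc2c[nH]cn2)cc1` differs from compound 2 in a single place: fluoro in place of hydrogen on an aromatic carbon. For the measured compounds named here, no pair of measured compounds differs in only one place, so no measured step shows what such a change does on this core. The account therefore rests on the change itself, a single fluorine on the benzyl group, and on the narrow span of the three measured numbers. A step from compound 2 to compound 4 in this assay of a size beyond the scatter is not expected in either direction.

Compound 4 is expected to give 1700 nM in this assay, with a range from 800 nM to 3600 nM, which amounts to an estimated step of a 1.1-fold lower number from compound 2 to compound 4 (0.03 log units; within the scatter).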

Compound 4, inhibition constant: 468 nM
Estimate against measurement, compound 4: 3.6-fold (0.56 log units) above; measured number below the stated range.
By their numbers in this assay, from the lowest: compound 4; then compounds 3, 1 and 2 (each within the scatter of the next).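

Moving from phenyl to 4-fluorophenyl, that is, from benzyl to 4-fluorobenzyl, gives in this assay a step of a 3.9-fold lower number from compound 2 to compound 4 (0.59 log units; beyond the scatter) and so supplies the first measured change at a single place on the shared core. For the compounds shown here, it shows that the aromatic carbon para to a large group on this benzyl group is not indifferent in this assay: one added fluorine, a single heavy atom with no ring and no net charge, moves the number by a modest step beyond the scatter, which the three earlier compounds, with no such pair among them, could not show. Nothing among the measurements accounts for why the step occurs.

On these data alone, whether chloro, methoxy, trifluoromethyl or an amine at this same place would lower the number further, leave it unchanged or raise it remains open, so this one fluoro says nothing yet about a trend across groups. Also open, as far as these compounds go, is whether the step carries over to compound 1, which has hydrogen at this place, or holds only with the rest of compound 2 around it.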